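This account rests on a few compounds, and the source may have more. Where it says the series, first, only, none or still open, it means among the compounds named here.

Measured in a functional assay on MCF7 cells (Homo sapiens) for cytotoxicity, read by MTT assay, with a stated time of 48 h; a higher number here means a weaker inhibitor, a lower number a stronger inhibitor:
Compound 1 `C/C(=N\NC(=S)Nc1ccc(Cl)cc1)c1ccccn1`: 8.49 nM
Compound 2 `C/C(=N/NC(=S)Nc1ccc(Cl)cc1)c1ccccn1`: 8.49 nM

In this assay compound 2 gives 8.49 nM, level with compound 1. Compound 3 `CC(=NNC(=S)Nc1ccc(Cl)cc1)c1ccccn1` is the next structure to compare with compound 2, and the difference is this: the two compounds have the same atoms and bonds; at least one stereo element is drawn with a configuration in one of them and without one in the other: 1 of 1 stereo elements differ; a double bond is drawn Z in compound 2 and without a configuration in compound 3. Going by the values given here, the one measured step that bears on this change is no change at the digits printed from compound 1 to compound 2 (within the scatter), and that pair is defined by the fact that compounds 1 and 2 differ only in the configuration as drawn. Swapping the drawn configuration there left the value unmoved, so no step beyond the scatter is expected in this assay. The expected result is no change at the digits printed from compound 2 to compound 3 (within the scatter). For compound 3 the estimated value is 8.49 nM, with an expected range of 5 nM to 14 nM.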

Compound 3, half-maximal inhibitory concentration: 8.5 nM
Estimate against measurement, compound 3: 1.0-fold (0.00 log units) below; measured number inside the range.
By their numbers in this assay, from the lowest: compounds 1, 2 and 3 (each within the scatter of the next).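

In this assay the two new steps are a 1.0-fold higher number from compound 2 to compound 3 (0.00 log units; within the scatter) and a 1.0-fold higher number from compound 1 to compound 3 (0.00 log units; within the scatter). The earlier pair compared only the two defined configurations of the double bond, whereas these steps add the form drawn without a configuration, and it too stands level with both. Drawing this double bond as defined or undefined therefore does not separate the compounds here: the fact that one of compounds 2 and 3 is drawn with a defined configuration and the other without, at the place where they differ

All three compounds share the same atoms and bonds, so the compounds shown leave open whether the value depends on the configuration alone or also on the groups around it. Nothing here tells what a methoxy group or a carboxylic acid in place of the chlorine would do.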